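Chloro to Methoxy: What Happens to Activity?

This account rests on a few compounds, and the source may have more. Where it says the series, first, only, none or still open, it means among the compounds named here.

Among the compounds with values here, in a functional assay on HCT-116 cells (Homo sapiens) for antiproliferative activity, read by MTT assay, with a stated time of 48 h (on this read-out higher numbers stand for weaker inhibition and lower numbers for stronger inhibition), compound 2 `CCCCCCCCCCC(CCO)n1cnc2c(Cl)ncnc21` gives 4930 nM, the only actual number so far. Compound 1 `CCCCC(CCO)n1cnc2c(OC)ncnc21`, which carries methoxy, reaches only a limit, > 50000 nM. Compound 3 `CCCCCCCCCCC(CCO)n1cnc2c(OC)ncnc21` comes from compound 2 through one change, methoxy in place of chloro on an aromatic carbon. Within the data shown here, no measured step isolates this change. Among the measured compounds shown here, the sole hint is compound 1 with its limit of > 50000 nM, which suggests weaker inhibition. The expected change is a 3.0-fold higher number from compound 2 to compound 3 (0.48 log units; beyond the scatter), a moderate weakening beyond the usual scatter. For compound 3 the estimated value is 15000 nM, with an expected range from 5000 nM to 50000 nM.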

Compound 3, half-maximal inhibitory concentration: 7530 nM
Compound 3: the middle estimate sits 2.0-fold (0.30 log units) above what was measured, within the range that was stated.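

In this assay, methoxy and chloro on this aromatic carbon cannot be told apart, with a 1.5-fold higher number from compound 2 to compound 3 (0.18 log units; within the scatter). With methoxy held in place, hexyl in place of hydrogen on the saturated chain gives an at least 6.6-fold lower number from compound 1 to compound 3 (0.82 log units; beyond the scatter), so here the chain makes the clearer difference. That step is only a bound, because compound 1 sits at a limit of the assay rather than at a number: the limit of > 50000 nM in this assay, at which 1 of the 3 values shown sits.

Still open, as far as these compounds go, is whether an amine on this aromatic carbon would give a step beyond the scatter. A longer chain than that of compound 3 also remains to be compared.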